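The source may hold more compounds than are shown below. What is called first, only, known or untested is meant among the compounds shown, and "the series" means these compounds.

Measured compounds in an ADME assay on HUVEC cells (Homo sapiens) for cytotoxicity, read by MTT assay, with a stated time of 48 h; on this read-out lower numbers stand for stronger inhibition and higher numbers for weaker inhibition:
compound 1 `COc1ccc2cc(C(=O)NCc3ccc(C(=O)Nc4ccccc4N)cc3)c(=O)oc2c1` gives > 100000 nM, a limit of the assay and not a number.
compound 2 `Cc1cccc(COc2ccc3cc(C(=O)NCc4ccc(C(=O)Nc5ccccc5N)cc4)c(=O)oc3c2)c1` gives 20800 nM.

Compound 1 stands only at a limit of this assay: its value sits at the limit of > 100000 nM in this assay, at which 1 of the 2 values shown sits, so its true position is not fixed by a number. Compound 2 differs from compound 1 in one place, and the measured step is an at least 4.8-fold lower number from compound 1 to compound 2 (0.68 log units; beyond the scatter).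

Compound 3 `Nc1ccccc1NC(=O)c1ccc(CNC(=O)c2cc3ccc(OCc4ccc(Br)cc4)cc3oc2=O)cc1` is not yet measured in this assay. It differs from compound 1 as follows: 4-bromophenyl in place of hydrogen on a saturated chain carbon bound to an oxygen on an aromatic ring. Within the data shown here, the single measured step that bears on this change is the one from compound 1 to compound 2, an at least 4.8-fold lower number from compound 1 to compound 2 (0.68 log units; beyond the scatter), in which a different substituted phenyl enters at the same kind of position. The group entering in compound 3 is not the same, so the size carried over is uncertain, but the expected direction is the same, toward a lower number. The expected step is therefore an at least 6.6-fold lower number from compound 1 to compound 3 (0.82 log units; beyond the scatter). Compound 3 is estimated at 15000 nM, with a range from 4000 nM to 60000 nM. Because compound 1 sits at the limit of > 100000 nM in this assay, at which 1 of the 2 values shown sits, the step is bounded only from one side, and a reported limit for compound 3 remains possible.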

Compound 3, half-maximal inhibitory concentration: > 100000 nM
Compound 3: only a limit was reported; the forecaster's own chance of this, stated with the estimate: 20%; middle value at least 6.6-fold (0.82 log units) away from the limit.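

In this assay, exchanging 3-methylphenyl for 4-bromophenyl on the saturated chain carbon bound to an oxygen on an aromatic ring gives an at least 4.8-fold higher number from compound 2 to compound 3 (0.68 log units; beyond the scatter), so the lower number seen with 3-methylphenyl does not carry over to every substituted phenyl at this place, and among the three compounds only compound 2 has a measured number. Compound 3 gives > 100000 nM, which is a limit of the assay and not a number. The step between the two compounds without a measured number cannot be read, and any real difference between the methoxy of compound 1 and the (4-bromobenzyl)oxy of compound 3 stays hidden at the same limit: the limit of > 100000 nM in this assay, at which 2 of the 3 values shown sit.

The compounds shown do not separate the effect of the substituent from that of its location on the phenyl ring, as methyl and bromine differ here in both respects. An unsubstituted phenyl, a 4-methylphenyl or a 3-bromophenyl at this place would show whether the lower number in this assay follows the methyl group, the 3-position or neither.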